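The source may hold more compounds than are shown below. What is called first, only, known or untested is meant among the compounds shown, and "the series" means these compounds.

In an ADME assay on MT4 cells (Homo sapiens) for cytotoxicity, read by MTT assay, with a stated time of 4 days (on this read-out higher numbers stand for lower toxicity in this test and lower numbers for higher toxicity in this test), compound 1 (`CC(=O)Nc1ccc2oc(-c3ccc(C(F)(F)F)cc3)cc(=O)c2c1`) gives 330000 nM and compound 2 (`COc1ccccc1-c1oc2ccc(NC(C)=O)cc2c(=O)c1O`) gives 385000 nM as its read-out. Compound 2 therefore sits level with compound 1, the two values lying within the usual scatter of repeated measurements. Compound 3 (`CC(=O)Nc1ccc2oc(-c3ccccc3F)c(O)c(=O)c2c1`) is still to be measured in this assay and keeps the rest of compound 2 with one change: fluoro in place of methoxy on an aromatic carbon, ortho to a large group (fluoro in place of methoxy on an aromatic carbon), so that 2-methoxyphenyl becomes 2-fluorophenyl. Within the data shown here, no measured pair differs in one place only, so this change has no direct precedent. Among the measured compounds shown here, the only guide is that compound 1 at 330000 nM and compound 2 at 385000 nM lie within the scatter of each other. On that basis no step beyond the scatter is expected in this assay and no direction is favoured. The estimated move, a 1.1-fold lower number from compound 2 to compound 3 (0.04 log units; within the scatter) in size, is expected to stay inside the scatter. For compound 3 the expected value is 350000 nM with an estimated range from 170000 nM to 650000 nM for this measurement.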

Compound 3, half-maximal cytotoxic concentration: 171000 nM
Beside the measured number, compound 3's estimate is 2.0-fold (0.31 log units) above it, and the stated range covers the measured number.
By their numbers in this assay, from the lowest: compounds 3, 1 and 2 (each within the scatter of the next, the first and the last beyond it).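

In this assay the series now has its first pair that differs in one place: with 2-methoxyphenyl becoming 2-fluorophenyl, the read-out shows a 2.3-fold lower number from compound 2 to compound 3 (0.35 log units; beyond the scatter) and so moves towards higher toxicity in this test. Among these compounds, this shows that the read-out responds to a single replacement on an aromatic carbon, ortho to a large group, and that fluoro in place of methoxy there gives a modest step beyond the scatter, which the earlier compounds, differing in more than one place, could not show. Nothing measured here accounts for this step.

With a single replacement shown at this position, the compounds leave open whether the step follows from methoxy leaving or from fluoro entering, and a chloro or methyl group in the same place would help to separate the two readings. Also open, on these data alone, is whether the same change gives a step of similar size and direction on the core of compound 1, since one pair cannot show how far this result carries across the series.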